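The source may report more compounds than this note shows. Statements on the series, on what has been measured and on what is new or still open speak of the compounds shown alone.

Measured so far in an assay on CHO cells for displacement of a labelled ligand from prostaglandin D2 receptor (Mus musculus), read by scintillation counting, with a stated time of 60 min; on this read-out lower numbers stand for stronger inhibition and higher numbers for weaker inhibition:
compound 1 `CN1C[C@@H](COc2ccc(C(=O)Nc3cccc(CC(=O)O)c3)c(Cl)c2)Oc2ccccc21` gives 16 nM
compound 2 `Cc1ccc(CC(=O)O)cc1NC(=O)c1ccc(OC[C@@H]2CN(C)c3ccccc3O2)cc1Cl` gives 26 nM
compound 3 `Cc1ccc(NC(=O)c2ccc(OC[C@@H]3CN(C)c4ccccc4O3)cc2Cl)cc1CC(=O)O` gives 17 nM

Compound 3 stands second highest of the three numbers, with compound 1 nearest and compound 2 furthest; both gaps lie within the scatter (a 1.1-fold higher number from compound 1 to compound 3 (0.03 log units; within the scatter); a 1.5-fold lower number from compound 2 to compound 3 (0.18 log units; within the scatter)). Compound 4 `CN1C[C@@H](COc2ccc(C(=O)Nc3ccc(F)c(CC(=O)O)c3)c(Cl)c2)Oc2ccccc21` is the next structure; it differs from compound 3 by fluoro in place of methyl on an aromatic carbon. Among the measured compounds shown here, none of the measured steps exchanges a methyl for a fluoro, so no direct precedent exists. The closest guidance comes from the methyl-for-hydrogen steps a 1.6-fold higher number from compound 1 to compound 2 (0.21 log units; within the scatter) and a 1.1-fold higher number from compound 1 to compound 3 (0.03 log units; within the scatter) and from the regrouping a 1.5-fold lower number from compound 2 to compound 3 (0.18 log units; within the scatter), each of which stays within the scatter; across these three compounds, changes on this ring have moved the number little. Given those three steps, the expected step in this assay is no change at the digits printed from compound 3 to compound 4 (within the scatter), that is, none beyond the scatter in either direction. Compound 4 is accordingly estimated at 17 nM, with a range from 7 nM to 40 nM.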

Compound 4, inhibition constant: 25 nM
For compound 4 the middle estimate is 1.5-fold (0.17 log units) below the measured one, within the range that was stated.
By their numbers in this assay, from the lowest: compounds 1, 3, 4 and 2 (each within the scatter of the next).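

In this assay, fluoro in place of methyl on this aromatic carbon, ortho to a carboxymethyl group and para to a large group, gives a 1.5-fold higher number from compound 3 to compound 4 (0.17 log units; within the scatter) and fluoro in place of hydrogen gives a 1.6-fold higher number from compound 1 to compound 4 (0.19 log units; within the scatter) so this carbon has now carried hydrogen, methyl and fluoro with no step beyond the scatter. The exchange of 5-(carboxymethyl)-2-methylphenyl for 3-(carboxymethyl)-4-fluorophenyl, which alters both the group and its place, gives a 1.0-fold lower number from compound 2 to compound 4 (0.02 log units; within the scatter) and also stays within the scatter. No supporting measurement accompanies these steps, so no cause can be assigned to them.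

The compounds shown leave open whether a methoxy, a nitrile or an amine on this carbon would move the number beyond the scatter. They also leave open what a longer chain, such as carboxyethyl, would do in place of carboxymethyl.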